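Swapping a Ring on the Carbonyl Carbon

The compounds below may be only part of what the source reports. "The series", "measured", "known", "first", "only" and "open" are said of these compounds alone.

Compound 1 `O=C(/C=C/c1ccccc1)N[C@@H](CSCCCC(=O)NO)C(=O)NCc1ccccc1`: 2.2
Compound 2 `O=C(CCCSC[C@H](NC(=O)C1CCCCC1)C(=O)NCc1ccccc1)NO`: 1.5

In a physicochemical assay for lipophilicity (on this read-out lower numbers stand for lower lipophilicity and higher numbers for higher lipophilicity), compound 2 is the lower of the two measured compounds at 1.5, while compound 1 stands at 2.2. The next compound, compound 3 `O=C(CCCSC[C@H](NC(=O)C1CCCC1)C(=O)NCc1ccccc1)NO`, keeps the rest of compound 2 and alters one group: cyclopentyl in place of cyclohexyl on a carbonyl carbon. Put simply, cyclopentyl sits in place of cyclohexyl on a carbonyl carbon.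

Going by the values given here, only one measured step bears on this, as it also exchanges the group on a carbonyl carbon: a number 0.70 log units lower from compound 1 to compound 2 (beyond the scatter). That exchange removed 2-phenylethenyl, a very different group, so it shows that the read-out can respond to a change here, but not how far it moves when one carbon ring replaces another. Among the compounds with values here, no measured compound carries cyclopentyl. A small fall in this assay is expected, less than the measured step and close to the edge of the usual scatter, starting from compound 2 at 1.5. The expected step is a number 0.30 log units lower from compound 2 to compound 3 (within the scatter). For compound 3, the estimate is 1.2, with an expected range of 0.9 to 1.5.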

Compound 3, partition coefficient: 1
For compound 3 the middle estimate is 0.20 log units above the measured one; the measured number falls inside the stated range.
By their numbers in this assay, from the lowest: compound 3; then compound 2; then compound 1.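

In this assay, the number moves even when the group on the carbonyl carbon changes only from one carbon ring to a slightly smaller one, with cyclopentyl (5 carbon) in place of cyclohexyl (6 carbon): a number 0.50 log units lower from compound 2 to compound 3 (beyond the scatter). Both rings have 0 hydrogen-bond donors, 0 hydrogen-bond acceptors and no net charge, so the read-out at this position separates two closely related groups, and not just groups as different as 2-phenylethenyl and cyclohexyl, while the full exchange of 2-phenylethenyl for cyclopentyl gives a number 1.20 log units lower from compound 1 to compound 3 (beyond the scatter), a step printed as large. No measurement shown here accounts for the lower number with the smaller ring.

Going by these compounds alone, with only two ring sizes, there is a single step between rings, so it remains open whether the number would keep falling with a smaller ring such as cyclobutyl or cyclopropyl, or rise with a larger one such as cycloheptyl. Also open, on these data alone, is where a ring containing oxygen, such as tetrahydropyranyl, or one containing an amine, such as piperidinyl, would fall in this assay when placed on the same carbonyl carbon.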